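The source may report more compounds than this note shows. Statements on the series, on what has been measured and on what is new or still open speak of the compounds shown alone.

Three amide variants on a shared core have been run in a functional assay on PC-3 cells (Homo sapiens) for inhibition, read by MTT assay, with a stated time of 72 h; on this read-out lower numbers stand for stronger inhibition and higher numbers for weaker inhibition. Compound 1 `O=C(CSc1nc(Nc2ccccc2)c2ccccc2n1)Nc1ccccc1Br` gives 19800 nM; compound 2 `O=C(CSc1nc(Nc2ccccc2)c2ccccc2n1)Nc1cccc([N+](=O)[O-])c1` gives 11800 nM; compound 3 `O=C(CSc1nc(Nc2ccccc2)c2ccccc2n1)Nc1ccc(C(F)(F)F)cc1` gives 10400 nM. Compound 3 holds the lowest of the three numbers, but the distances are small: a 1.1-fold lower number from compound 2 to compound 3 (0.05 log units; within the scatter) and a 1.9-fold lower number from compound 1 to compound 3 (0.28 log units; within the scatter), and between the other two a 1.7-fold lower number from compound 1 to compound 2 (0.22 log units; within the scatter). None of the three exchanges on the amide-type nitrogen moves this assay beyond the scatter, so the three compounds cannot be ordered on these numbers.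

Compound 4 `CCc1ccc(NC(=O)CSc2nc(Nc3ccccc3)c3ccccc3n2)cc1` differs from compound 3 in one place: ethyl in place of trifluoromethyl on an aromatic carbon. Among the compounds with values here, no measured pair changes a substituent at this position while keeping the rest of the aryl; the three steps that exist all exchange the whole aryl on the amide-type nitrogen, and all sit within the scatter, so they give no direction for the change, only the observation that this part of the molecule has so far been tolerant of variation. The expected step in this assay is therefore no larger than the scatter, a 1.0-fold lower number from compound 3 to compound 4 (0.02 log units; within the scatter). Compound 4 is estimated at 10000 nM, with a range of 4000 nM to 30000 nM.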

Compound 4, half-maximal inhibitory concentration: 17900 nM
For compound 4 the middle estimate is 1.8-fold (0.25 log units) below the measured one; low and high end bracket the measured number.
By their numbers in this assay, from the lowest: compounds 3, 2, 4 and 1 (each within the scatter of the next).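

Within the data shown here, the exchange of trifluoromethyl for ethyl on an aromatic carbon, para to a large group, is the first pair to change a substituent while keeping the rest of the aryl, and in this assay it gives a 1.7-fold higher number from compound 3 to compound 4 (0.24 log units; within the scatter). The 4-ethylphenyl group also stays inside the scatter when set against the other two aryl groups on the amide-type nitrogen, with a 1.5-fold higher number from compound 2 to compound 4 (0.18 log units; within the scatter) and a 1.1-fold lower number from compound 1 to compound 4 (0.04 log units; within the scatter), so compound 4 joins the other three without an order among them, and this position now tolerates a direct substituent exchange as well as whole-aryl exchanges. The data shown hold no measurement that bears on this result.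

Still open, on these data alone, is whether an amine, a carboxylic acid or a chain longer than ethyl at this position would give a step beyond the scatter in this assay. Also open, as far as these compounds go, is whether an exchange on the shared core, away from the aryl on the amide-type nitrogen, would separate compounds where these aryl exchanges do not.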